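Adding Three Methyl Groups to a Weakly Active Sulfonyl Hydrazide

The compounds below may be only part of what the source reports. "The series", "measured", "known", "first", "only" and "open" are said of these compounds alone.

Compound 2 `CC[C@H](C)[C@H](NC(=O)c1cccc(Cn2ccnc2)c1)C(=O)NNS(=O)(=O)c1ccccc1` shows only a small effect where it has been tested: in an assay on HEK293 cells for displacement of a labelled ligand from Type-2 angiotensin II receptor (Homo sapiens), tested at 1 uM (on this read-out higher numbers stand for a stronger effect at the one concentration tested and lower numbers for a weaker effect), compound 2 gives 6%. Its closest relative, compound 3 `CC[C@H](C)[C@H](NC(=O)c1cccc(Cn2ccnc2)c1)C(=O)NC#N`, gives 6% in this assay, and the step of no change at the digits printed from compound 2 to compound 3 (within the scatter) shows that exchanging the group on the amide-type nitrogen moved the read-out not at all. A third compound, compound 1 `CCCCNC(=O)[C@@H](NC(=O)c1cccc(Cn2ccnc2)c1)[C@@H](C)CC`, is reported in this assay as "not active" (no number reported), with no number attached.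

Compound 4 `CC[C@H](C)[C@H](NC(=O)c1cccc(Cn2ccnc2)c1)C(=O)NNS(=O)(=O)c1c(C)cc(C)cc1C` differs from compound 2 in one place: 2,4,6-trimethylphenyl in place of phenyl on a sulfonyl sulfur. For the measured compounds named here, no measured step touches the ring on the sulfonyl sulfur, so the only direct guidance comes from the other end of the same side chain, where the change from compound 2 to compound 3 stayed within the scatter. Nothing among the three measured compounds points to a strong effect from this core. Because the step of no change at the digits printed from compound 2 to compound 3 (within the scatter) was flat, compound 4 is expected to give 8% in this assay, within a range from 0% to 25%. For compound 4 the expected step is a number 2 percentage points higher from compound 2 to compound 4 (within the scatter).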

Compound 4, a percentage reported as inhibition, at one concentration (the size of the read-out at that concentration, not a potency): 10%
For compound 4 the middle estimate is 2 percentage points below the measured one; the measured number falls inside the stated range.
By their numbers in this assay, from the lowest: compounds 2, 3 and 4 (each within the scatter of the next).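

For the compounds shown here, this is the first look at the ring on the sulfonyl sulfur, a place the earlier compounds left unchanged. In this assay, swapping phenyl for 2,4,6-trimethylphenyl, which takes the ring substituent from 6 to 9 heavy atoms, gives a number 4 percentage points higher from compound 2 to compound 4 (within the scatter), so the three extra methyl groups leave the read-out within the usual scatter. This position therefore accepts a bulkier carbon-only ring without any clear gain or loss in the effect at the one concentration tested, and no evidence is available to explain this result.

Still open, going by these compounds, is whether a ring carrying a different kind of group, such as a carboxylic acid or an amine, would move the read-out beyond the scatter. Also open is whether any change to the shared core would do more, and a single-concentration read-out gives no potency for any of these compounds.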